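Mirror Image of a Phosphate Serine Diamide

The source may hold more compounds than are shown below. What is called first, only, known or untested is meant among the compounds shown, and "the series" means these compounds.

Within the data shown here, compound 2 `CCCCCCCCNC(=O)[C@H](COP(=O)(O)O)NC(=O)CCCCCCC` is the only compound here with a number: in an assay on RH7777 cells with lysophosphatidic acid receptor 3 (Homo sapiens) as the target (on this read-out lower numbers stand for stronger inhibition and higher numbers for weaker inhibition), compound 2 gives 414 nM. Compound 1 `CCCCCCCCOC[C@H](COP(=O)(O)O)OCCCCCCCC` stands in this assay only as "not determined" (no result reported). Compound 3 `CCCCCCCCNC(=O)[C@@H](COP(=O)(O)O)NC(=O)CCCCCCC` is the mirror image of compound 2: the two compounds have the same atoms and bonds and differ only in configuration as drawn: 1 of 1 stereo elements differ; a stereocentre at a saturated chain carbon is drawn S in compound 2 and R in compound 3. Among the measured compounds shown here, no measured step of this kind exists in this set to calibrate the change, so the expectation is a cautious one, that the reversed configuration weakens inhibition modestly, a step of a 2.2-fold higher number from compound 2 to compound 3 (0.34 log units; beyond the scatter) that is estimated rather than known. Compound 3 is therefore expected to give about 900 nM, within a range from 250 nM to 5000 nM.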

Compound 3, half-maximal inhibitory concentration: 935 nM
Estimate against measurement, compound 3: 1.0-fold (0.02 log units) below; measured number inside the range.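

Reversing the single stereocentre gives a 2.3-fold higher number from compound 2 to compound 3 (0.35 log units; beyond the scatter) in this assay, so this position responds to configuration, but only modestly: the S form as drawn has the lower number, and the R form still gives a measurable value. The shift can be assigned to this one stereocentre because nothing else separates the two structures: the fact that compounds 2 and 3 differ only in the configuration as drawn

As far as these compounds go, whether the same preference would hold with a longer chain on either amide, or with a carboxylic acid in place of the phosphate, remains open. Compound 1 has no number, so it adds nothing to this comparison.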